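The compounds below may be only part of what the source reports. "The series", "measured", "known", "first", "only" and "open" are said of these compounds alone.

Compound 3 `Cc1ccc(-n2c(Nc3nc(-c4ccc(Cl)cc4)cs3)n[nH]c2=S)cc1` is one of three close relatives tested in a functional assay on the whole organism (strain Swiss albino) for inhibition, with Mus musculus as the target, with a stated time of 4 h; a higher number here means that more compound is needed for the effect, a lower number that less compound is needed. In this assay compound 3 gives 300 mg/kg, compound 1 `S=c1[nH]nc(Nc2nc(-c3ccc(Br)cc3)cs2)n1-c1ccccc1` gives 300 mg/kg, and compound 2 `Cc1ccc(-n2c(Nc3nc(-c4ccc([N+](=O)[O-])cc4)cs3)n[nH]c2=S)cc1` gives 300 mg/kg, so all three stand level within the scatter. Compound 4 `Cc1ccc(-n2c(Nc3nc(-c4ccc(Br)cc4)cs3)n[nH]c2=S)cc1` differs from compound 3 by bromo in place of chloro on an aromatic carbon. Within the data shown here, the only measured step, no change at the digits printed from compound 2 to compound 3 (within the scatter), exchanged one group on an aromatic carbon and left the dose unchanged. Compound 1, which carries the bromo group that enters here, also sits at the same level as compound 3. The step of no change at the digits printed from compound 3 to compound 4 (within the scatter) is therefore expected to remain within the scatter, with no change in direction. Compound 4 is estimated at 300 mg/kg, within a range of 150 mg/kg to 600 mg/kg.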

Compound 4, minimum effective dose: 300 mg/kg
Estimate against measurement, compound 4: no gap at the digits printed; the measured number falls inside the stated range.
By their numbers in this assay, from the lowest: compounds 1, 2, 3 and 4 (each within the scatter of the next).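

Bromo in place of chloro gives no change at the digits printed from compound 3 to compound 4 (within the scatter) in this assay and bromo in place of nitro gives no change at the digits printed from compound 2 to compound 4 (within the scatter) on the same ring carbon, so chloro, bromo and nitro now read alike at this position. Methyl in place of hydrogen on an aromatic carbon, with bromo kept, gives no change at the digits printed from compound 1 to compound 4 (within the scatter) as well, so a second place also shows no shift.

On these data alone, whether an amine or a carboxylic acid at the place of the bromo would shift the dose stays open, as all four compounds stand level. No measurement in hand speaks to why the dose holds steady.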